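Chain extension on the saturated carbon of compound 2

The source may hold more compounds than are shown below. What is called first, only, known or untested is meant among the compounds shown, and "the series" means these compounds.

Three compounds of the shared core have numbers in a functional assay on L1210 cells (Mus musculus), with a stated time of 12 days; on this read-out higher numbers stand for higher potency (the scale is a negative logarithm) and lower numbers for lower potency. Compound 1 `CCCC1=C(N2CC2)C(=O)C(C(COC(N)=O)OC)=C(N2CC2)C1=O` gives 5.07. Compound 3 `CCOC(COC(N)=O)C1=C(N2CC2)C(=O)C(C)=C(N2CC2)C1=O` gives 5.22. Compound 2 `CC1=C(N2CC2)C(=O)C(Cc2ccccc2)=C(N2CC2)C1=O` gives 4.69, the lowest of the three, lying beyond the scatter below both compound 1 and compound 3.

Compound 4 `CC1=C(N2CC2)C(=O)C(CCCc2ccccc2)=C(N2CC2)C1=O` has not yet been measured. Its difference from compound 2 is phenethyl in place of phenyl on a saturated chain carbon bound to a double-bonded ring carbon. For the measured compounds named here, no measured pair shows this change, so no step of this kind is known in the set. The step is expected to be small, estimated as a number 0.16 log units higher from compound 2 to compound 4 (within the scatter), a slight rise that may well stay within the scatter. Compound 4 is therefore expected to give about 4.85, with a range from 4.4 to 5.3.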

Compound 4, logarithm of the reciprocal of the active concentration, log(1/C): 4.21
For compound 4 the middle estimate is 0.64 log units above the measured one; measured number below the stated range.
By their numbers in this assay, from the lowest: compound 4; then compound 2; then compounds 1 and 3 (each within the scatter of the next).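

In this assay, phenethyl in place of phenyl on a saturated chain carbon bound to a double-bonded ring carbon gives a number 0.48 log units lower from compound 2 to compound 4 (beyond the scatter), so this position is sensitive to the change and lengthening here costs potency. That reading rests on this single pair. Nothing available explains the drop.

From the compounds shown here alone, whether a still longer chain lowers the number further remains open. So does whether an amine or a carboxylic acid in place of phenyl would hold or recover potency at this position.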